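This account rests on a few compounds, and the source may have more. Where it says the series, first, only, none or still open, it means among the compounds named here.

In a functional assay on HCT-116 cells (Homo sapiens) for antiproliferative activity, read by MTT assay, with a stated time of 72 h (on this read-out lower numbers stand for stronger inhibition and higher numbers for weaker inhibition), compound 1 `COc1cccc(-c2cccc(NC(=O)CCc3ccc4c(c3)B(O)OC4)c2)c1` gives 21000 nM, while compound 2 `COc1cc(OC)cc(-c2cccc(NC(=O)CCc3ccc4c(c3)B(O)OC4)c2)c1` gives 3700 nM, the lower of the two numbers. Among the measured compounds shown here, the only measured step is a 5.7-fold lower number from compound 1 to compound 2 (0.75 log units; beyond the scatter), where a methoxy takes the place of hydrogen on an aromatic carbon. Compound 3 `CC(=O)c1ccc(-c2cccc(NC(=O)CCc3ccc4c(c3)B(O)OC4)c2)cc1` keeps the shared core and carries 4-acetylphenyl in place of 3,5-dimethoxyphenyl on an aromatic carbon. For the measured compounds named here, this removes both methoxy groups, so the measured step bears on the change only in part, and no measured compound shows what the acetyl contributes. Loss of the methoxy added in that step points towards a higher number in this assay, of modest size. The estimate is a 2.7-fold higher number from compound 2 to compound 3 (0.43 log units; beyond the scatter), an expected move towards weaker inhibition. For compound 3 the expected value is 10000 nM, within an estimated range of 3000 nM to 30000 nM.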

Compound 3, half-maximal inhibitory concentration: 19000 nM
Compound 3: middle estimate off by 1.9-fold (0.28 log units), on the low side, and the stated range covers the measured number.
By their numbers in this assay, from the lowest: compound 2; then compounds 3 and 1 (each within the scatter of the next).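

In this assay, the 3,5-dimethoxyphenyl group does not tolerate exchange for 4-acetylphenyl at this place on the aromatic carbon, since the change gives (a 5.1-fold higher number from compound 2 to compound 3 (0.71 log units; beyond the scatter)) and the earlier gain is gone. Set against the 3-methoxyphenyl group, the same 4-acetylphenyl group gives (a 1.1-fold lower number from compound 1 to compound 3 (0.04 log units; within the scatter)), so compound 1 and compound 3 cannot be told apart on this read-out, and among the three groups only 3,5-dimethoxyphenyl stands apart. Nothing measured here speaks to what lies behind these numbers.

On these data alone, it remains open whether the acetyl group or its place on the ring governs the number of compound 3, as the names of the groups differ in both. As far as these compounds go, it is also open how an amine, a hydroxyl or a carboxylic acid on this ring would compare with the two methoxy groups of compound 2.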